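Swapping fluoro for methoxycarbonyl in a kinase inhibitor

This account rests on a few compounds, and the source may have more. Where it says the series, first, only, none or still open, it means among the compounds named here.

Compound 1, `CN(C)c1ccc(C(=O)Nc2cccc(NC(=O)COc3ccc4c(c3)CCC(=O)N4)c2)cc1`: 9970 nM
Compound 2, `Cc1c(OCC(=O)Nc2cccc(NC(=O)c3ccc(N(C)C)cc3)c2)ccc2c(=O)ccoc12`: 4160 nM
Compound 3, `O=C(COc1ccc2c(=O)ccoc2c1)Nc1cccc(NC(=O)c2ccc(F)cc2)c1`: 54 nM

In an assay on isolated protein for inhibition of Rho-associated protein kinase 2 (Homo sapiens), read by scintillation counting, radiometric assay and 33P incorporation, with a stated time of 40 min, in the presence of a further agent that is not named here (a higher number here means a weaker inhibitor, a lower number a stronger inhibitor), compound 3 gives the lowest number of the three, and its gaps to compound 2 and to compound 1 both lie well beyond the usual scatter of repeated measurements, so among these three it is the strongest inhibitor. Compound 4, `COC(=O)c1ccc(C(=O)Nc2cccc(NC(=O)COc3ccc4c(=O)ccoc4c3)c2)cc1`, differs from compound 3 in a single place: methoxycarbonyl in place of fluoro on an aromatic carbon. Among the measured compounds shown here, no pair of measured compounds isolates this particular change. Compounds 1 and 2 carry a different group at that position and also differ from compound 3 in their core, so their values show only that both are far weaker than compound 3 and say nothing specific about the new group. For the measured compounds named here, with no direct precedent, the change is expected to be modest, leaning slightly toward a weaker inhibitor, as a 2.8-fold higher number from compound 3 to compound 4 (0.44 log units; beyond the scatter). Compound 4 is therefore estimated to give about 150 nM, with a plausible range from 40 nM to 600 nM.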

Compound 4, half-maximal inhibitory concentration: 29 nM
The estimate for compound 4 lay 5.2-fold (0.71 log units) above the measured number; measured number outside the range, below it.
By their numbers in this assay, from the lowest: compounds 4 and 3 (each within the scatter of the next); then compound 2; then compound 1.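

In this assay, among the compounds shown here, the change from 4-fluorophenyl to 4-(methoxycarbonyl)phenyl gives a 1.9-fold lower number from compound 3 to compound 4 (0.27 log units; within the scatter) and is the first direct reading at this position, on an aromatic carbon para to a large group. The entering methoxycarbonyl brings 4 heavy atoms and 2 hydrogen-bond acceptors where a single fluorine stood, yet the two compounds cannot be ranked, so the position accepts the larger group with no measurable loss or gain. No measurement offered here explains this tolerance.

Still open, as far as these compounds go, is whether a carboxylic acid, a primary amide or a plain hydrogen at the same place would also keep the number this low. From the compounds shown here alone, it is equally open how far the position stretches, for instance to an ethyl or longer ester chain in place of the methyl of the ester.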